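Swapping Phenyl for Hydrogen in Compound 3

This account rests on a few compounds, and the source may have more. Where it says the series, first, only, none or still open, it means among the compounds named here.

In a functional assay on PC-3 cells (Homo sapiens) for antiproliferative activity, read by MTT assay, with a stated time of 48 h (a higher number here means a weaker inhibitor of growth, a lower number a stronger inhibitor of growth), compound 1 (`CCOc1cc(NC(=O)CCCCCC(=O)Nc2cc(-c3ccccc3)ccc2N)cc2c1OCC([N+](=O)[O-])=C2`) gives 7080 nM and compound 2 (`CCOc1cc(NC(=O)CCCCC(=O)Nc2cc(-c3ccccc3)ccc2N)cc2c1OCC([N+](=O)[O-])=C2`) gives 14600 nM and compound 3 (`CCOc1cc(NC(=O)CCCCCCC(=O)Nc2cc(-c3ccccc3)ccc2N)cc2c1OCC([N+](=O)[O-])=C2`) gives 10700 nM as its value. Compound 3 thus stands within the usual scatter of both others, so these three numbers show no real separation. Compared with compound 3, compound 4 (`CCOc1cc(NC(=O)CCCCCCC(=O)Nc2ccccc2N)cc2c1OCC([N+](=O)[O-])=C2`) has hydrogen in place of phenyl on an aromatic carbon and is otherwise the same. For the measured compounds named here, no measured pair here shows this change, so its effect remains uncertain. A step no larger than the usual scatter is expected in this assay with neither direction favoured. The estimated step is a 1.2-fold lower number from compound 3 to compound 4 (0.08 log units; within the scatter) and it could prove larger. The estimated value for compound 4 is 9000 nM (expected range 2800 nM to 28000 nM).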

Compound 4, concentration for 50% growth inhibition: 8630 nM
Compound 4: the middle estimate sits 1.0-fold (0.02 log units) above what was measured; measured number inside the range.
By their numbers in this assay, from the lowest: compounds 1, 4, 3 and 2 (each within the scatter of the next, the first and the last beyond it).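

In this assay, hydrogen in place of phenyl gives a 1.2-fold lower number from compound 3 to compound 4 (0.09 log units; within the scatter) and so stays within the usual scatter. For the compounds shown here, at this aromatic carbon, on this chain, the phenyl can therefore be removed without a change beyond the scatter, something the earlier compounds, which all carry it, could not show. No measurement at hand explains this result. Still open, as far as these compounds go, is whether a fluorine or a methoxy group on this carbon would move the number. Also open, from the compounds shown here alone, is whether the same swap behaves alike on the shorter chains of compound 1 and compound 2.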